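Removing the diol of compound 3: an expectation for compound 4

The source may hold more compounds than are shown below. What is called first, only, known or untested is meant among the compounds shown, and "the series" means these compounds.

Compound 3 `C=CC(C)(C)c1[nH]c2ccc(C[C@@H](O)C(C)(C)O)cc2c1/C=C1\NC(=O)[C@H](C)NC1=O` gives 79000 nM in a functional assay (a lower number here means a stronger inhibitor, a higher number a weaker inhibitor), level with compound 1 `C=CC(C)(C)c1[nH]c2ccc(C[C@@H](O)C(C)(C)Cl)cc2c1/C=C1\NC(=O)[C@H](C)NC1=O` at 79000 nM and close to compound 2 `C=CC(C)(C)c1[nH]c2ccc(C[C@@H](O)C(=C)C)cc2c1/C=C1\NC(=O)[C@H](C)NC1=O` at 75000 nM. The three differ only at the end of the side chain on the shared core, and every step among them stayed within the scatter: a 1.1-fold lower number from compound 1 to compound 2 (0.02 log units; within the scatter), no change at the digits printed from compound 1 to compound 3 (within the scatter) and a 1.1-fold higher number from compound 2 to compound 3 (0.02 log units; within the scatter). Compound 4 `C=CC(C)(C)c1[nH]c2ccc(CC=C(C)C)cc2c1/C=C1\NC(=O)[C@H](C)NC1=O` carries a shorter change at the same chain: 2-methylprop-1-en-1-yl in place of 1,2-dihydroxy-2-methylpropyl on a saturated chain carbon bound to an aromatic carbon. The measured steps alter only the outer carbon of that chain, and none removes both oxygens, so they bear on this change only in part. Compound 4 is therefore expected to show a 1.1-fold lower number from compound 3 to compound 4 (0.02 log units; within the scatter), no step beyond the scatter. The estimate for compound 4 is 75000 nM, in the range 30000 nM to 160000 nM.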

Compound 4, half-maximal inhibitory concentration: 98000 nM
Compound 4: the middle estimate sits 1.3-fold (0.12 log units) below what was measured; the range from low to high includes it.
By their numbers in this assay, from the lowest: compounds 2, 1, 3 and 4 (each within the scatter of the next).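

In this assay removing both oxygens of the chain, not only altering its outer carbon, gives a step within the scatter (a 1.2-fold higher number from compound 3 to compound 4 (0.09 log units; within the scatter)). Compound 4 also stays within the scatter of the two other chain ends (a 1.3-fold higher number from compound 2 to compound 4 (0.12 log units; within the scatter); a 1.2-fold higher number from compound 1 to compound 4 (0.09 log units; within the scatter)), so in these compounds the inner hydroxy group, like the outer substituent, can go without a step beyond the scatter. No evidence here bears on this result.

Going by these compounds, whether any group at this place can move the number beyond the scatter stays open. An amine, a carboxylic acid or a longer chain on the saturated chain carbon bound to an aromatic carbon would test that.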